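The source may hold more compounds than are shown below. What is called first, only, known or untested is meant among the compounds shown, and "the series" means these compounds.

Measured so far in an ADME assay (liver) for metabolic stability, with Liver microsome (Rattus norvegicus) as the target, read by LC-MS, using microsomes and NADPH, with stated times of 5 min and 60 min, tested at 4 uM; on this read-out higher numbers stand for a more stable compound and lower numbers for a less stable compound:
compound 1 `Cc1c(OCCCCOCOc2ccc(C(=O)O)cc2)ccc(C(=O)CC2CCCC2)c1O` gives 31%
compound 2 `Cc1c(OCCCCOc2ccc(C(=O)O)cc2Cl)ccc(C(=O)CC2CCCC2)c1O` gives 21%
compound 3 `Cc1cc(C(=O)O)ccc1OCCCCOc1ccc(C(=O)CC2CCCC2)c(O)c1C` gives 59%

Compound 3 stands highest of the three at 59% here, and its gaps to both others lie beyond the scatter. Compound 4 `Cc1cc(OCCCCOc2ccc(C(=O)CC3CCCC3)c(O)c2C)ccc1C(=O)O` has the same atoms joined differently, with 4-carboxy-3-methylphenyl in place of 4-carboxy-2-methylphenyl on an oxygen on a saturated carbon as the whole change. Within the data shown here, no measured step shifts a methyl group in this way. The nearest evidence is a number 38 percentage points higher from compound 2 to compound 3 (beyond the scatter) as a large step and a number 28 percentage points higher from compound 1 to compound 3 (beyond the scatter) as a modest one. Both show that this assay responds to changes in this part of the molecule, but neither gives a direction here. A small step is therefore expected, a number 7 percentage points lower from compound 3 to compound 4 (within the scatter) by estimate, with a wide margin. For compound 4 the expected value is 52% within a range of 32% to 72% as an estimate.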

Compound 4, percent of the compound remaining: 55%
Compound 4: middle estimate off by 3 percentage points, on the low side, and the stated range covers the measured number.
By their numbers in this assay, from the lowest: compounds 2 and 1 (each within the scatter of the next); then compounds 4 and 3 (each within the scatter of the next).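

Shifting the methyl, with 4-carboxy-3-methylphenyl in place of 4-carboxy-2-methylphenyl, gives in this assay a number 4 percentage points lower from compound 3 to compound 4 (within the scatter), so this read-out does not separate the two methylphenyl isomers. The gain over the chloro compound holds for the shifted isomer, with a number 34 percentage points higher from compound 2 to compound 4 (beyond the scatter). The same holds against the longer link of compound 1, with a number 24 percentage points higher from compound 1 to compound 4 (beyond the scatter).

As far as these compounds go, whether a methoxy or a fluoro group in place of the methyl would keep this level stays open. That these two isomers sit together stays unexplained. No supporting data bear on this result.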